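Bromo in Place of Hydrogen on the Benzyl Ring

The source may report more compounds than this note shows. Statements on the series, on what has been measured and on what is new or still open speak of the compounds shown alone.

Measured compounds:
compound 1 `Cc1cc(Nc2ccc(C(=O)/C=C/c3ccc4ccccc4c3)cc2)n2nc(SCc3ccccc3)nc2n1` – 300 nM
compound 2 `Cc1cc(Nc2ccc(C(=O)/C=C/c3ccc4ccccc4c3)cc2)n2nc(SCc3ccccc3[N+](=O)[O-])nc2n1` – 960 nM

Among the measured compounds shown here, compound 1 is the stronger of the two compounds measured so far in a functional assay on SW-620 cells (Homo sapiens) for cytotoxicity, read by MTT assay, with stated times of 4 h and 72 h, tested at 5 uM; a higher number here means a weaker inhibitor, a lower number a stronger inhibitor; its nearest neighbour is compound 2, and the step of a 3.2-fold higher number from compound 1 to compound 2 (0.51 log units; beyond the scatter) lies beyond the scatter. Compound 3 `Cc1cc(Nc2ccc(C(=O)/C=C/c3ccc4ccccc4c3)cc2)n2nc(SCc3ccccc3Br)nc2n1` has not yet been measured. It differs from compound 1 in one place: bromo in place of hydrogen on an aromatic carbon. The change sits on an aromatic carbon of a six-membered aromatic ring of carbon only, ortho to a large group, the same position that carries the nitro group in compound 2.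

For the measured compounds named here, the only step that bears on this change is the one from compound 1 to compound 2, where a nitro group entered at this position and gave a 3.2-fold higher number from compound 1 to compound 2 (0.51 log units; beyond the scatter), a modest weakening. Going by the values given here, a bromo substituent is a different group, and no second example of a substituent at this position is available, so the direction is uncertain. A modest rise in this assay, smaller than or similar to that seen for compound 2, is the expectation, so compound 3 is estimated at 500 nM, within 200 nM to 1200 nM, corresponding to the expected step of a 1.7-fold higher number from compound 1 to compound 3 (0.22 log units; within the scatter).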

Compound 3, half-maximal inhibitory concentration: 420 nM
For compound 3 the middle estimate is 1.2-fold (0.08 log units) above the measured one; measured number inside the range.
By their numbers in this assay, from the lowest: compounds 1 and 3 (each within the scatter of the next); then compound 2.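

With a bromo group on this aromatic carbon, ortho to a large group, this assay shows a 1.4-fold higher number from compound 1 to compound 3 (0.15 log units; within the scatter), so here, unlike with the nitro group, substitution gives no difference from hydrogen that can be told from the scatter. The comparison between the two substituents at this same place adds what the first pair could not show: a 2.3-fold lower number from compound 2 to compound 3 (0.36 log units; beyond the scatter), which means that among these compounds the reading depends on which group enters and not merely on the position being occupied, with compound 2 alone standing apart from the other two. Nothing available here explains why the bromo and nitro groups differ in this way.

With only two substituents at this position, the compounds shown cannot establish any trend, and it remains open whether a methoxy group, an amine or a carboxylic acid on this carbon would read like bromo or like nitro. They also say nothing about a fluoro or chloro group here, or about a bromo group on any other carbon of the benzyl ring.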